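4-Methoxyphenyl to thiophen-2-yl at the assay limit

The compounds below may be only part of what the source reports. "The series", "measured", "known", "first", "only" and "open" are said of these compounds alone.

Measured in a toxicity assay on HeLa cells (Homo sapiens) for cytotoxicity, read by MTT assay, with a stated time of 3 h; on this read-out higher numbers stand for weaker inhibition and lower numbers for stronger inhibition:
Compound 1 `COc1ccc(C2=[N+]3C(=Nc4c(-c5ccccc5)c5c(n4[B-]3(F)F)-c3ccc(OC)cc3CC5)C(c3ccccc3)=C2Br)cc1`: > 50000 nM
Compound 2 `COc1ccc2c(c1)CCc1c(-c3ccccc3)c3n(c1-2)[B-](F)(F)[N+]1=C(c2ccc(C)s2)C(Br)=C(c2ccccc2)C1=N3`: > 50000 nM
Compound 3 `COc1ccc(C2=[N+]3C(=Nc4c(-c5ccccc5)c5c(n4[B-]3(F)F)-c3ccc(OC)cc3CC5)C(c3ccccc3)=C2I)cc1`: > 50000 nM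

All three values are limits of the assay, not numbers. Compound 3 stands only at a limit, > 50000 nM. Compound 4 `COc1ccc2c(c1)CCc1c(-c3ccccc3)c3n(c1-2)[B-](F)(F)[N+]1=C(c2cccs2)C(I)=C(c2ccccc2)C1=N3` differs from it by thiophen-2-yl in place of 4-methoxyphenyl on a carbon with a double bond to nitrogen, with thiophen-2-yl in place of 4-methoxyphenyl on a carbon with a double bond to nitrogen. The nearest measured change is a step that the two limits leave unreadable from compound 1 to compound 2, where 5-methylthiophen-2-yl replaces 4-methoxyphenyl. The other is a step that the two limits leave unreadable from compound 1 to compound 3, where iodo replaces bromo. Neither has a readable size, and the evidence amounts to the limit of > 50000 nM in this assay, at which 3 of the 3 values shown sit. For the measured compounds named here, no step of known size or direction is therefore expected in this assay. The expected change is a step that the limit leaves unreadable from compound 3 to compound 4. Compound 4 is estimated at 70000 nM, with an expected range of 30000 nM to 150000 nM.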

Compound 4, half-maximal inhibitory concentration: > 50000 nM
Compound 4 ended at the assay's limit; the forecaster's own chance of this, stated with the estimate: 90%; the middle value is on the limit's open side.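

Compound 3 and compound 4 both stand at a limit of this assay, not at a number, and no step can be read between them. The compounds shown leave open how far each lies beyond that limit, and whether any of these changes alters cytotoxicity.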